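The compounds below may be only part of what the source reports. "The series", "measured", "known", "first", "only" and "open" are said of these compounds alone.

Measured so far:
Compound 1 `COc1ccc(-c2ccc(NC3=CC(=O)c4ncncc4C3=O)cc2)cc1` — in a functional assay on PANC-1 cells (Homo sapiens) for cytotoxicity, read by MTT assay, with a stated time of 72 h (a higher number here means a weaker inhibitor, a lower number a stronger inhibitor), compound 1 gives 2300 nM.
Compound 2 `COc1ccc(NC2=CC(=O)c3ncncc3C2=O)cc1` — in this assay compound 2 gives 800 nM.

Among the compounds with values here, the single measured step, a 2.9-fold lower number from compound 1 to compound 2 (0.46 log units; beyond the scatter), leaves compound 2 holding the lower of the two numbers. Compound 3 `NS(=O)(=O)c1ccc(NC2=CC(=O)c3ncncc3C2=O)cc1` differs from compound 2 by sulfamoyl in place of methoxy on an aromatic carbon. Within the data shown here, no measured step concerns this exchange; the one known step, a 2.9-fold lower number from compound 1 to compound 2 (0.46 log units; beyond the scatter), alters a different part of the molecule and offers no guide. Compound 3 is therefore expected to give about 900 nM in this assay, likely between 250 nM and 3500 nM. This expected outcome corresponds to a 1.1-fold higher number from compound 2 to compound 3 (0.05 log units; within the scatter), nothing beyond the scatter.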

Compound 3, half-maximal inhibitory concentration: > 10000 nM
Compound 3: no number, only a limit; the forecaster's own chance of this, stated with the estimate: 5%; middle value at least 11-fold (1.04 log units) from the limit.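

At this aromatic carbon, para to a large group, sulfamoyl in place of methoxy gives an at least 12-fold higher number from compound 2 to compound 3 (1.09 log units; beyond the scatter), so the choice of group here can matter far more than the earlier step suggested. Sulfamoyl in place of 4-methoxyphenyl likewise gives an at least 4.3-fold higher number from compound 1 to compound 3 (0.63 log units; beyond the scatter). The result for compound 3 is a limit and not a number: the limit of > 10000 nM in this assay, at which 1 of the 3 values shown sits.

The compounds shown leave open whether the sulfonyl part or the terminal nitrogen of sulfamoyl goes with this change. They also leave open how an amine or a carboxylic acid would read at this carbon.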